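The source may hold more compounds than are shown below. What is called first, only, known or untested is meant among the compounds shown, and "the series" means these compounds.

Measured so far:
compound 1, `Cc1cc(Oc2ccc(/C=N/NC(=S)Nc3ccc(F)cc3)cc2)ccc1Cl` — 6.07
compound 2, `Cc1ccc(Oc2ccc(/C=N/NC(=S)Nc3ccc(Cl)cc3)cc2)cc1` — 5.97

In a physicochemical assay for lipophilicity, in phosphate buffer, measured as octanol-water partition, with a stated time of 24 h (a higher number here means a more lipophilic compound, a lower number a more polar compound), compound 2 gives 5.97, and compound 1 gives 6.07; the two numbers sit within the scatter of each other, so neither compound can be set apart from the other on this measurement.

The next compound, compound 3, `Cc1cc(Oc2ccc(/C=N/NC(=S)Nc3ccc(Cl)cc3)cc2)ccc1Cl`, differs from compound 2 in one place: 4-chloro-3-methylphenyl in place of 4-methylphenyl on an oxygen on an aromatic ring. Among the measured compounds shown here, no measured pair shows this change, so there is no directly comparable step to lean on. The expectation is that compound 3 will read above compound 2 in this assay, with a step of about a number 0.58 log units higher from compound 2 to compound 3 (beyond the scatter), which would be clearly beyond the scatter. Compound 3 is estimated at 6.55, with a range from 6.1 to 7.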

Compound 3, partition coefficient: 6.59
Beside the measured number, compound 3's estimate is 0.04 log units below it; the measured number falls inside the stated range.
By their numbers in this assay, from the lowest: compounds 2 and 1 (each within the scatter of the next); then compound 3.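

In this assay, 4-chloro-3-methylphenyl in place of 4-methylphenyl on an oxygen on an aromatic ring gives a number 0.62 log units higher from compound 2 to compound 3 (beyond the scatter). Chloro in place of fluoro on an aromatic carbon gives a number 0.52 log units higher from compound 1 to compound 3 (beyond the scatter), so the series now has two single-place changes that both register on this read-out, which compound 1 and compound 2 alone could not show, as they differ in more than one place. Nothing available explains either step.

Each change appears only once, and the compounds shown do not separate how the first step divides between the chloro and the methyl of the entering group. As far as these compounds go, how the read-out would respond to an amine or a carboxylic acid on that aromatic carbon also remains open.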